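Replacing 1H-benzimidazol-2-yl in compound 3

A few compounds are considered here, and "the series" means these few. Any claim that something is new, unique, unknown or untested is made for them only; others in the source may bear on it.

Measured in an ADME assay on microsomes from liver (Homo sapiens) for metabolic stability, read by LC-MS, with a stated time of 10 min, tested at 0.5 uM; a lower number here means that less of the compound is left, a higher number that more of the compound is left:
Compound 1 `c1ccc2c(c1)CN[C@@H](CN(CCCN1CCNCC1)[C@H]1CCCc3cccnc31)C2`: 100%
Compound 2 `c1cnc2c(c1)CCC[C@@H]2N(CCCN1CCNCC1)Cc1cc2ccccc2cn1`: 66%
Compound 3 `c1cnc2c(c1)CCC[C@@H]2N(CCCN1CCNCC1)Cc1nc2ccccc2[nH]1`: 63%

Compound 3, at 63%, stands level with compound 2 and clearly under compound 1. Compound 4 `c1cnc2c(c1)CCC[C@@H]2N(CCCN1CCNCC1)Cc1nc2ccccc2s1` differs from it in one place: 1,3-benzothiazol-2-yl in place of 1H-benzimidazol-2-yl on a saturated chain carbon bound to an amine nitrogen. This puts 1,3-benzothiazol-2-yl in place of 1H-benzimidazol-2-yl on a saturated chain carbon bound to an amine nitrogen. The nearest evidence is the exchange of isoquinolin-3-yl for 1H-benzimidazol-2-yl, a number 3 percentage points lower from compound 2 to compound 3 (within the scatter). The large steps, a number 34 percentage points lower from compound 1 to compound 2 (beyond the scatter) and a number 37 percentage points lower from compound 1 to compound 3 (beyond the scatter), both leave 1,2,3,4-tetrahydroisoquinolin-3-yl and bear less on this change. The estimated step is a number 5 percentage points lower from compound 3 to compound 4 (within the scatter), so none beyond the scatter is expected. In this assay, compound 4 is expected at 58%, within an estimated range from 40% to 76%.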

Compound 4, percent of the compound remaining: 50%
Compound 4: the middle estimate sits 8 percentage points above what was measured, and the stated range covers the measured number.
By their numbers in this assay, from the lowest: compound 4; then compounds 3 and 2 (each within the scatter of the next); then compound 1.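

In this assay, the aromatic groups on this saturated chain carbon are no longer all level: 1,3-benzothiazol-2-yl gives a number 13 percentage points lower from compound 3 to compound 4 (beyond the scatter) and a number 16 percentage points lower from compound 2 to compound 4 (beyond the scatter), while isoquinolin-3-yl and 1H-benzimidazol-2-yl stayed within the scatter of each other. Set against 1,2,3,4-tetrahydroisoquinolin-3-yl, the same group gives a number 50 percentage points lower from compound 1 to compound 4 (beyond the scatter). No measurement at hand accounts for these differences. From the compounds shown here alone, whether 1,3-benzoxazol-2-yl would read with 1,3-benzothiazol-2-yl or with 1H-benzimidazol-2-yl stays open, as does how a saturated amine such as piperidin-2-yl would compare with 1,2,3,4-tetrahydroisoquinolin-3-yl.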